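The compounds below may be only part of what the source reports. "The series", "measured", "known", "first", "only" and "open" are said of these compounds alone.

Of the compounds shown here, three that share one core have been tested in a functional assay on the whole organism with Rattus norvegicus as the target, at a dose of 100 mg/kg; a lower number here means less inhibition, a higher number more inhibition at the dose given (going by the name of the read-out). Compound 1, `C/N=C(/NC#N)NCCCCn1nc(N(C)C)ccc1=O`, carries a dimethylamino group on that core and gives 26.3% in this assay. Compound 2, `CC/N=C(/NC#N)NCCCn1nc(-c2ccccc2)ccc1=O`, carries a phenyl group on the core with a different linking chain and gives 62.9%. Compound 3, `CC/N=C(/NC#N)NCCCCCCn1nc(-c2ccccc2)ccc1=O`, also carries a phenyl group, again with a chain of another length, and gives 29.1%. Among these three numbers compound 1 sits lowest. Its value and that of compound 3 lie within the usual scatter of each other, so no order can be read between them, while compound 2 stands beyond the scatter above compound 1.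

Compound 4, `C/N=C(/NC#N)NCCCCn1nc(-c2ccc(Cl)cc2)ccc1=O`, is the next step from compound 1. The change is 4-chlorophenyl in place of dimethylamino on an aromatic carbon. For the measured compounds named here, no measured pair shows this exact change, so its effect can only be inferred. The two compounds that carry an aromatic group in that place, compound 2 and compound 3, one lying within the scatter of compound 1 and one far above it, differ from compound 4 in their chains as well, so the comparison is loose. A rise in this assay is expected, probably beyond the scatter, with the step estimated at a number 18.7 percentage points higher from compound 1 to compound 4 (beyond the scatter). Compound 4 is therefore expected to give about 45%, somewhere between 20% and 70%.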

Compound 4, a percentage reported as inhibition, in the whole organism at one dose (the size of the read-out at that dose, not a potency): 51%
Compound 4: the middle estimate sits 6 percentage points below what was measured, and the stated range covers the measured number.
By their numbers in this assay, from the lowest: compounds 1 and 3 (each within the scatter of the next); then compound 4; then compound 2.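

For the compounds shown here, with the chain and the rest of the molecule held the same, this pair isolates the group on this aromatic carbon for the first time: in this assay, putting 4-chlorophenyl in place of dimethylamino gives a number 24.7 percentage points higher from compound 1 to compound 4 (beyond the scatter). The earlier compounds shown here could not show this, as those carrying an aromatic group on this carbon also had different chains, so the effect of the group could not be separated from the effect of the chain. The pair shows that the group at this position can by itself move the inhibition seen at this single dose, although nothing available explains why this change raises the number.

Going by these compounds, what remains open is whether the ring or the chlorine on it accounts for the step, a question that a plain phenyl group on this same chain would help to answer. It is also unknown how a different group at this carbon, such as 4-methoxyphenyl or a cyclic amine like morpholine, would compare with dimethylamino and 4-chlorophenyl.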